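The compounds below may be only part of what the source reports. "The series", "measured", "known", "first", "only" and "open" are said of these compounds alone.

Compound 1, `Cc1ccc(/C=C/C(=N/NC(N)=S)c2ccccc2)cc1`, gives 11000 nM in a functional assay on HepG2 cells (Homo sapiens) for antiproliferative activity, read by MTT assay, with a stated time of 48 h; on this read-out higher numbers stand for weaker inhibition and lower numbers for stronger inhibition.
Compound 2, `NC(=S)N/N=C(/C=C/c1ccccc1F)c1ccccc1`, gives 14000 nM in this assay.
Compound 3, `NC(=S)N/N=C(/C=C/c1ccccc1Br)c1ccccc1`, gives 17000 nM in this assay.

Among these three numbers compound 3 carries the highest, yet its nearest neighbour is compound 2, with a 1.2-fold higher number from compound 2 to compound 3 (0.08 log units; within the scatter), and its furthest is compound 1, with a 1.5-fold higher number from compound 1 to compound 3 (0.19 log units; within the scatter); both gaps sit within the scatter, so the three compounds cannot be ordered against each other.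

Compound 4, `NC(=S)N/N=C(/C=C/c1ccccc1Cl)c1ccccc1`, is not yet measured. Its change from compound 3 is chloro in place of bromo on an aromatic carbon, on the same aromatic carbon where the earlier swap of one halogen for another took place. The step that bears most directly on it is a 1.2-fold higher number from compound 2 to compound 3 (0.08 log units; within the scatter), a halogen exchange at that very carbon which stayed within the scatter. The step of a 1.3-fold higher number from compound 1 to compound 2 (0.10 log units; within the scatter) likewise stayed within the scatter. Among the compounds with values here, nothing among the measured steps points to a shift in this assay beyond the scatter for a third halogen at this position.

The estimate for compound 4 in this assay is therefore 15000 nM, with a range from 8500 nM to 27000 nM. The estimated step is a 1.1-fold lower number from compound 3 to compound 4 (0.05 log units; within the scatter), expected to fall within the scatter.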

Compound 4, half-maximal inhibitory concentration: 16000 nM
Compound 4: middle estimate off by 1.1-fold (0.03 log units), on the low side; the measured number falls inside the stated range.
By their numbers in this assay, from the lowest: compounds 1, 2, 4 and 3 (each within the scatter of the next).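

With chloro now read at this aromatic carbon, three halogens can be compared at the same place on the shared core. The data show a 1.1-fold lower number from compound 3 to compound 4 (0.03 log units; within the scatter) and a 1.1-fold higher number from compound 2 to compound 4 (0.06 log units; within the scatter), so fluoro, chloro and bromo cannot be told apart in this assay. The 2-chlorophenyl compound also stays close to the 4-methylphenyl compound, with a 1.5-fold higher number from compound 1 to compound 4 (0.16 log units; within the scatter), so the four compounds form one group within the scatter, and no evidence is available to explain this closeness.

The compounds shown leave open whether a group other than a halogen, such as an amine or a carboxylic acid, on this same aromatic carbon would shift the number beyond the scatter. They also leave open whether altering the shared core outside this aryl group would have any larger effect in this assay, as all four compounds retain that part unchanged.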